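Replacing the naphthylmethyl group of compound 3 with 3-fluorophenyl

The compounds below may be only part of what the source reports. "The series", "measured", "known", "first", "only" and "open" are said of these compounds alone.

Measured so far in an ADME assay on HEK-293T cells (Homo sapiens) for inhibition, read by CCK-8 assay, with a stated time of 48 h, tested at 20 uM; on this read-out lower numbers stand for less inhibition of growth and higher numbers for more inhibition of growth at the one concentration tested
- compound 1 `COc1ccc(Cc2nnc(NC(=O)/C(C#N)=C/c3ccccc3OS(=O)(=O)c3ccc(Cl)cc3)s2)cc1` gives 34%
- compound 2 `N#C/C(=C\c1ccccc1OS(=O)(=O)c1ccc([N+](=O)[O-])cc1)C(=O)Nc1nnc(Cc2cccc3ccccc23)s1` gives 25%
- compound 3 `N#C/C(=C\c1ccccc1OS(=O)(=O)c1ccc(Cl)cc1)C(=O)Nc1nnc(Cc2cccc3ccccc23)s1` gives 16%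

Compound 3 stands level with compound 2 within the scatter, and below compound 1 beyond it. The next compound, compound 4 `N#C/C(=C\c1ccccc1OS(=O)(=O)c1ccc(Cl)cc1)C(=O)Nc1nnc(-c2cccc(F)c2)s1`, carries 3-fluorophenyl in place of (naphthalen-1-yl)methyl on an aromatic carbon. Two measured steps are available. The exchange of chloro for nitro gave a number 9 percentage points lower from compound 2 to compound 3 (within the scatter), but it lies elsewhere in the molecule and says little here. More relevant is the step that introduced the naphthalen-1-yl group, a number 18 percentage points lower from compound 1 to compound 3 (beyond the scatter), a modest change beyond the scatter. Losing that group may recover part of this difference, but no measured compound has an aryl group bound directly to the core, so the expectation is loose. A small rise in this assay is expected, near the edge of the scatter. The estimated change is a number 11 percentage points higher from compound 3 to compound 4 (beyond the scatter). For compound 4 the expected value is 27%, with an estimated range from 10% to 45%.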

Compound 4, percent growth inhibition at one concentration: 29%
For compound 4 the middle estimate is 2 percentage points below the measured one; the measured number falls inside the stated range.
By their numbers in this assay, from the lowest: compounds 3, 2, 4 and 1 (each within the scatter of the next, the first and the last beyond it).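

Exchanging (naphthalen-1-yl)methyl for 3-fluorophenyl in this assay gave a number 13 percentage points higher from compound 3 to compound 4 (beyond the scatter), which shows that this position on the core affects the read-out and that an aryl group bound directly to the core is compatible with growth inhibition at the level seen for the benzyl compound. The second step, a number 5 percentage points lower from compound 1 to compound 4 (within the scatter), places 3-fluorophenyl level with 4-methoxybenzyl, so these two groups are not told apart here, and among the chloro compounds only the naphthalene-bearing compound 3 stands apart. Nothing measured here offers an explanation for this shift.

Among these compounds, the single exchange alters both the ring and its link to the core, so the contributions of the fluorine and the lost methylene remain unseparated. As far as these compounds go, what an amine or a longer chain would give at this position also stays open.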